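From dipropylamino to dibutylamino on a shared core

The source may report more compounds than this note shows. Statements on the series, on what has been measured and on what is new or still open speak of the compounds shown alone.

Measured in a functional assay (aorta) with Rattus norvegicus as the target; on this read-out higher numbers stand for weaker inhibition and lower numbers for stronger inhibition:
Compound 1 `COc1ccc(NCCCOc2ccc(S(=O)(=O)c3c(C(C)C)cn4ccccc34)cc2)cc1OC`: 396 nM
Compound 2 `CCCN(CCC)CCCOc1ccc(S(=O)(=O)c2c(C(C)C)cn3ccccc23)cc1`: 102 nM
Not yet measured: compound 3 `CCCCN(CCCC)CCCOc1ccc(S(=O)(=O)c2c(C(C)C)cn3ccccc23)cc1`

For the measured compounds named here, of the two numbers so far in this assay, compound 2 has the lower, at 102 nM, and so shows the stronger inhibition. Compound 3 departs from compound 2 in one place: dibutylamino in place of dipropylamino on a saturated chain carbon, three bonds along the chain from an oxygen on an aromatic ring. It carries dibutylamino in place of dipropylamino on a saturated chain carbon, three bonds along the chain from an oxygen on an aromatic ring.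

Going by the values given here, only one measured step touches this place: a 3.9-fold lower number from compound 1 to compound 2 (0.59 log units; beyond the scatter). That step brought in dipropylamino for (3,4-dimethoxyphenyl)amino, a different exchange from the one here, so it offers only a loose guide. Among the compounds with values here, with a 3.9-fold lower number from compound 1 to compound 2 (0.59 log units; beyond the scatter) as the sole evidence, no step beyond the scatter is expected in this assay, and the direction stays open. The expected step is a 1.1-fold lower number from compound 2 to compound 3 (0.05 log units; within the scatter). For compound 3 the estimated value is 90 nM, with an expected range from 35 nM to 230 nM.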

Compound 3, half-maximal inhibitory concentration: 21.6 nM
Beside the measured number, compound 3's estimate is 4.2-fold (0.62 log units) above it; measured number outside the range, below it.
By their numbers in this assay, from the lowest: compound 3; then compound 2; then compound 1.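

In this assay, this position responds to a change as small as lengthening both alkyl groups on the amine: dibutylamino in place of dipropylamino gives a 4.7-fold lower number from compound 2 to compound 3 (0.67 log units; beyond the scatter). Measured against the (3,4-dimethoxyphenyl)amino group, the change is an 18-fold lower number from compound 1 to compound 3 (1.26 log units; beyond the scatter), which leaves compound 3 with the lowest number of the three, its steps to both others beyond the scatter. Nothing among the data shown explains why the dibutylamino group gives the lower number.

On these data alone, whether dipentylamino would lower the number further, or whether a cyclic amine such as piperidin-1-yl would match dibutylamino, stays open. Also open, as far as these compounds go, is whether the step from dipropylamino to dibutylamino would hold with a shorter or longer chain between the aromatic oxygen and the amine.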